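A chloro group on a weak growth inhibitor

The source may hold more compounds than are shown below. What is called first, only, known or untested is meant among the compounds shown, and "the series" means these compounds.

In a functional assay on NCI-H460 cells (Homo sapiens) for inhibition, read by sulforhodamine B assay, with a stated time of 48 h (on this read-out lower numbers stand for stronger inhibition of growth and higher numbers for weaker inhibition of growth), compound 2 (`CC(C)(C)NCc1c(C(=O)O)nn(-c2ccccc2)c1-c1ccc(F)cc1`) is recorded only as a limit, > 680000 nM, and a further entry for it also gives no single number. Its true value is therefore unknown.

Compound 3 (`CC(C)(C)NCc1c(C(=O)O)nn(-c2ccc(Cl)cc2)c1-c1ccc(F)cc1`) differs from it in one place: phenyl becomes 4-chlorophenyl, with chloro in place of hydrogen on an aromatic carbon, para to a large group (chloro in place of hydrogen on an aromatic carbon).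

Compound 1 (`CCOC(=O)c1nn(-c2ccc(Cl)cc2)c(-c2ccc(F)cc2)c1CNC(C)(C)C`), which also carries the 4-chlorophenyl group, gives 344000 nM; > 537000 nM (2 entries) in this assay. These are still very high concentrations, which means weak inhibition.

Among the compounds with values here, no pair of measured compounds isolates this change, so the step of an at least 1.2-fold lower number from compound 2 to compound 3 (0.09 log units; that floor lies within the scatter) is expected to stay within the usual scatter. For compound 3 the estimate is 550000 nM, with an expected range of 250000 nM to 900000 nM.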

Compound 3, concentration for 50% growth inhibition: > 623000 nM
Compound 3 gave a limit, no number (the forecaster's own chance of this, stated with the estimate: 65%); middle value at least 1.1-fold (0.05 log units) away from the limit.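

Compound 2 and compound 3 are both recorded only as limits in this assay, and the step between them cannot be read. The compounds shown leave open whether going from phenyl to 4-chlorophenyl changes growth inhibition at all.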